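Nitro to Methyl: An Expected Loss in Potency

The source may hold more compounds than are shown below. What is called first, only, known or untested is meant among the compounds shown, and "the series" means these compounds.

Compound 1, `COc1cc(-n2cnc3ccc(-c4ccc([N+](=O)[O-])cc4)cc32)cc(OC)c1OC`, is the most potent of the three compounds measured: in a functional assay on SGC-7901 cells (Homo sapiens) for antiproliferative activity, read by MTT assay, with a stated time of 72 h (on this read-out higher numbers stand for weaker inhibition and lower numbers for stronger inhibition), compound 1 gives 79 nM. Compound 2, `COc1cc(-n2cnc3ccc(-c4ccc(C(F)(F)F)cc4)cc32)cc(OC)c1OC`, gives 890 nM in this assay, and compound 3, `COc1cc(-n2cnc3ccc(-c4cccc(F)c4)cc32)cc(OC)c1OC`, gives 2490 nM. Both steps away from compound 1 lose potency clearly: an 11-fold higher number from compound 1 to compound 2 (1.05 log units; beyond the scatter), and a 32-fold higher number from compound 1 to compound 3 (1.50 log units; beyond the scatter); between the two weaker compounds, a 2.8-fold higher number from compound 2 to compound 3 (0.45 log units; beyond the scatter).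

Compound 4, `COc1cc(-n2cnc3ccc(-c4ccc(C)cc4)cc32)cc(OC)c1OC`, has not yet been measured. It differs from compound 1 in one place: methyl in place of nitro on an aromatic carbon

The measured steps bear on this change only indirectly, since none of them replaces nitro with methyl. Going by the values given here, still, the one step that keeps the phenyl group in place and only changes the group on it, trifluoromethyl in place of nitro, raised the number by a large amount. On that basis, a large rise in number is expected for compound 4 in this assay as well, though its size is uncertain.

Compound 4 is therefore estimated at 700 nM in this assay, with a range from 150 nM to 3000 nM. The step this estimate implies is an 8.9-fold higher number from compound 1 to compound 4 (0.95 log units; beyond the scatter), expected to lie beyond the scatter.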

Compound 4, half-maximal inhibitory concentration: 200 nM
Compound 4: middle estimate off by 3.5-fold (0.54 log units), on the high side, and the stated range covers the measured number.
By their numbers in this assay, from the lowest: compound 1; then compound 4; then compound 2; then compound 3.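

Going by these compounds alone, with methyl on this aromatic carbon, para to a large group, much of the potency of compound 1 is kept in this assay: the step of a 2.5-fold higher number from compound 1 to compound 4 (0.40 log units; beyond the scatter) is modest, whereas trifluoromethyl alone had given an 11-fold higher number from compound 1 to compound 2 (1.05 log units; beyond the scatter) at the same place, so nitro is not the only group here that keeps the number low, though compound 1 remains the most potent of the four. The two groups that earlier looked like a single loss of potency now separate, with a 4.5-fold lower number from compound 2 to compound 4 (0.65 log units; beyond the scatter) on going from trifluoromethyl to methyl, and the order among these three para groups runs nitro, methyl, trifluoromethyl, with the lowest number first. The step of a 12-fold lower number from compound 3 to compound 4 (1.10 log units; beyond the scatter) is large as well, but it changes both the group and its place on the phenyl ring, and no measurement at hand offers a reason for any of these differences.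

Going by these compounds, whether a nitrile, an amine or a carboxylic acid at this para carbon would come as close to compound 1 as methyl does, or closer, remains open. Also open, on these data alone, is how much of the weakness of compound 3 belongs to fluorine itself and how much to where it sits.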